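Swapping a benzyloxy for a pyrrolidinyl amide

A few compounds are considered here, and "the series" means these few. Any claim that something is new, unique, unknown or untested is made for them only; others in the source may bear on it.

The measurements come from an ADME assay on SH-SY5Y cells (Homo sapiens) for cytotoxicity, read by MTT assay, with a stated time of 48 h; a lower number here means a stronger inhibitor, a higher number a weaker inhibitor. Three compounds have been measured so far:

Compound 1, `COc1ccc(C(=O)/C=C/c2ccc(C(=O)NCc3ccccc3)cc2)c(O)c1`, gives > 100000 nM, which is a limit of the assay and not a number.
Compound 2, `CCOCCOc1ccc(/C=C/C(=O)c2ccc(OC)cc2O)cc1`, gives > 100000 nM, again a limit.
Compound 3, `COc1ccc(C(=O)/C=C/c2ccc(OCc3ccccc3)cc2)c(O)c1`, gives > 100000 nM, again a limit.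

Compound 3 thus stands at the limit of > 100000 nM in this assay, at which 3 of the 3 values shown sit, with nothing to set it apart from the other two. Among the measured compounds shown here, the one measured step, a step that the two limits leave unreadable from compound 2 to compound 3, is itself unreadable. Compound 4, `COc1ccc(C(=O)/C=C/c2ccc(C(=O)N3CCCC3)cc2)c(O)c1`, differs from compound 3 by (pyrrolidin-1-yl)carbonyl in place of benzyloxy on an aromatic carbon. For the measured compounds named here, no measured step bears on this change, and every value shown is a limit, so no shift beyond the scatter in this assay is expected; another limit is the likeliest outcome. The estimate for compound 4 is 150000 nM, between 60000 nM and 400000 nM. The step this expectation implies is a step that the limit leaves unreadable from compound 3 to compound 4.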

Compound 4, half-maximal inhibitory concentration: > 100000 nM
Compound 4 was reported as a limit; the forecaster's own chance of this, stated with the estimate: 85%; the middle value does not contradict the limit.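

Compound 4 is also a limit, so its steps from compound 1, compound 2 and compound 3 cannot be read: the limit of > 100000 nM in this assay, at which 4 of the 4 values shown sit.

The compounds shown leave open how these four rank against one another, and which change to the shared core, if any, would give a readable number.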